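Aminoquinoline ether series: cyclopentyl ether estimate

A few compounds are considered here, and "the series" means these few. Any claim that something is new, unique, unknown or untested is made for them only; others in the source may bear on it.

Measured compounds:
compound 1 `CC1CCCC(Oc2cccc3ccc(N)nc23)C1` with 640 nM
compound 2 `CCC(C)COc1cccc2ccc(N)nc12` with 36 nM
compound 3 `Nc1ccc2cccc(OCC3CC4CCC3C4)c2n1` with 137 nM

All three share the same core and differ only in the group on the ether oxygen. In an assay on cells with melanin-concentrating hormone receptor 1 (Homo sapiens) as the target, read by radioligand binding (on this read-out lower numbers stand for stronger inhibition and higher numbers for weaker inhibition), compound 2 gives the lowest of the three numbers, 36 nM. Compound 3 sits nearest to it, with 137 nM, a gap beyond the scatter, and compound 1 lies furthest away at 640 nM, also beyond the scatter. On these three values compound 2 is the most potent of the set.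

Compound 4 `Nc1ccc2cccc(OC3CCCC3)c2n1` is not yet measured. Against compound 2 it carries cyclopentyl in place of 2-methylbutyl on an oxygen on an aromatic ring. The group that leaves and the group that enters are equal in heavy-atom count, but the entering one forms one five-membered non-aromatic ring of carbon only where the 2-methylbutyl has no ring.

The two measured compounds whose ether substituents are not open chains, compound 1 and compound 3, both give higher numbers than compound 2, so a modest loss is expected for the step from compound 2 to compound 4, a 3.3-fold higher number from compound 2 to compound 4 (0.52 log units; beyond the scatter), beyond the scatter but smaller than the gap to compound 1. Compound 4 is estimated at 120 nM, within 40 nM to 350 nM.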

Compound 4, half-maximal inhibitory concentration: > 2000 nM
Compound 4 gave a limit, no number; the forecaster's own chance of this, stated with the estimate: 3%; middle value at least 16-fold (1.22 log units) away from the limit.
By their numbers in this assay, from the lowest: compound 2; then compound 3; then compound 1. At a limit, above all of these: compound 4.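

In this assay compound 4 gives a limit and not a number: the limit of > 2000 nM in this assay, at which 1 of the 4 values shown sits.

Going by these compounds alone, this is the first step that can be read at a single place, and it is large: with cyclopentyl in place of 2-methylbutyl on an oxygen on an aromatic ring, the step is an at least 55-fold higher number from compound 2 to compound 4 (1.74 log units; beyond the scatter), although the heavy-atom count stays equal, neither group carries hydrogen-bond donors or acceptors, and neither carries a net charge, which leaves the five-membered ring as the only counted difference. A ring in the ether group does not by itself decide the outcome, since compound 1 gives 640 nM and compound 3 gives 137 nM, so the values at this position depend on more than the presence of a ring.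

As far as these compounds go, it remains open whether cyclopentylmethyl on the same oxygen would read closer to compound 2 or to compound 4, which would help separate the ring itself from the way it is attached. The compounds shown also leave open how a smaller ring such as cyclobutyl, or an ether group carrying an amine, would read.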